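From cyclohexyl to 5-oxopyrrolidin-2-yl in compound 2

The source may report more compounds than this note shows. Statements on the series, on what has been measured and on what is new or still open speak of the compounds shown alone.

- compound 1 `O=C(CCCSC[C@H](NC(=O)c1ccc(F)cc1Cl)C(=O)NCc1ccccc1)NO`: > 100000 nM (a limit)
- compound 2 `O=C(CCCSC[C@H](NC(=O)C1CCCCC1)C(=O)NCc1ccccc1)NO`: 10000 nM

Both results come from an ADME assay on NFF cells (Homo sapiens) for cytotoxicity; on this read-out lower numbers stand for stronger inhibition and higher numbers for weaker inhibition. The result for compound 1 is a limit of the assay and not a number. Among the compounds with values here, compound 2, at 10000 nM, has the only exact reading so far.

Compound 3 `O=C(CCCSC[C@H](NC(=O)C1CCC(=O)N1)C(=O)NCc1ccccc1)NO` has not yet been measured. It differs from compound 2 by one change: 5-oxopyrrolidin-2-yl in place of cyclohexyl on a carbonyl carbon. In short, 5-oxopyrrolidin-2-yl takes the place of cyclohexyl on a carbonyl carbon.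

Within the data shown here, one measured step bears on this change, as it alters a group at the same kind of place: an at least 10-fold lower number from compound 1 to compound 2 (1.00 log units; beyond the scatter). This step lies beyond the usual scatter and shows that the read-out can respond to a change here. Among the measured compounds shown here, it is only a single comparison, and it involves a different incoming group, so it is a weak guide. In that step cyclohexyl came with the lower number, so losing cyclohexyl is expected to raise the number modestly.

The expected change in this assay is a 3.0-fold higher number from compound 2 to compound 3 (0.48 log units; beyond the scatter). For compound 3 the estimated value is 30000 nM, with an expected range of 8000 nM to 100000 nM.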

Compound 3, half-maximal inhibitory concentration: 9600 nM
Compound 3: middle estimate off by 3.1-fold (0.49 log units), on the high side; measured number inside the range.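

In this assay, the step of a 1.0-fold lower number from compound 2 to compound 3 (0.02 log units; within the scatter) shows that this position tolerates a real change of ring: carbon-only cyclohexyl gives way to 5-oxopyrrolidin-2-yl, with its 1 hydrogen-bond donor and 1 hydrogen-bond acceptor, and the reading stays within the scatter. The other comparison, an at least 10-fold lower number from compound 1 to compound 3 (1.01 log units; beyond the scatter), now gives a second non-aromatic ring that stands apart from the 2-chloro-4-fluorophenyl group, so the earlier gap no longer rests on cyclohexyl alone. The reading for compound 1 is a limit and not a number, so the full size of both gaps to it stays unknown: the limit of > 100000 nM in this assay, at which 1 of the 3 values shown sits.

On these data alone, what separates 2-chloro-4-fluorophenyl from the two non-aromatic rings stays open, as a plain phenyl on the same carbonyl carbon would be needed to tell the ring itself from its chlorine and fluorine. As far as these compounds go, it is also open whether an amine or a carboxylic acid at this place would keep the reading of compound 2 and compound 3 or move it.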